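Methoxy in place of methyl on compound 1

The source may report more compounds than this note shows. Statements on the series, on what has been measured and on what is new or still open speak of the compounds shown alone.

Compound 1 `Cc1ccc(N2CCn3c2n[nH]c(=O)c3=O)cc1` stands lowest of the two numbers measured in a functional assay on A549 cells (Homo sapiens) for antiproliferative activity, with a stated time of 72 h, tested at 50 ug/mL; a higher number here means a stronger effect of the compound at the concentration tested, a lower number a weaker effect: compound 1 gives 31%. Compound 2 `N=c1c(=O)[nH]nc2n1CCN2c1cccc(Cl)c1` gives 50% in this assay, a gap beyond the scatter. Compound 3 `COc1ccc(N2CCn3c2n[nH]c(=O)c3=O)cc1` differs from compound 1 only by methoxy in place of methyl on an aromatic carbon. Among the measured compounds shown here, no step between measured compounds shows this change, so the expected step is small, none beyond the scatter, in either direction; the estimated step of a number 4 percentage points higher from compound 1 to compound 3 (within the scatter) reflects this. Compound 3 is therefore estimated at 35%, with a range from 15% to 55% in this assay.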

Compound 3, a percentage reported as inhibition, at one concentration (the size of the read-out at that concentration, not a potency): 0%
Compound 3: the middle estimate sits 35 percentage points above what was measured; the whole stated range lies above it.
By their numbers in this assay, from the lowest: compound 3; then compound 1; then compound 2.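

Methoxy in place of methyl on the aromatic carbon para to a large group gives a number 31 percentage points lower from compound 1 to compound 3 (beyond the scatter) in this assay, so this position does not accept every small exchange on the core of compound 1. The entering group brings one more heavy atom, an oxygen, and one hydrogen-bond acceptor, and this single pair cannot separate the two. No measurement here bears on the reason for the loss.

Open, from the compounds shown here alone, is whether a hydroxyl, an ethyl or a chlorine at this position would keep the read-out of compound 1. Going by these compounds, how an amine or a carboxylic acid would behave there also remains open.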